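This account rests on a few compounds, and the source may have more. Where it says the series, first, only, none or still open, it means among the compounds named here.

Compound 3 `CNC(=O)c1cc(Oc2cccc(NC(=S)Nc3ccc(OC(F)(F)F)cc3)c2)ccn1` stands at the ceiling of a functional assay on MDA-MB-231 cells (Homo sapiens) for cytotoxicity, read by MTT assay, with a stated time of 48 h; a higher number here means a weaker inhibitor, a lower number a stronger inhibitor: its value of > 100000 nM is a limit of the assay and not a number. Compound 1 `CNC(=O)c1cc(Oc2cccc(NC(=S)Nc3ccc(Cl)cc3)c2)ccn1` is likewise reported only as a limit, at > 100000 nM. Compound 2 `CC(C)NC(=O)c1cc(Oc2cccc(NC(=S)Nc3ccc(Cl)cc3)c2)ccn1` gives a number in this assay, 87500 nM. Two of the three values shown sit at the same boundary, (the limit of > 100000 nM in this assay, at which 2 of the 3 values shown sit). The step from compound 1 to compound 3, a step that the two limits leave unreadable from compound 1 to compound 3, is not readable.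

Compound 4 `CC(C)NC(=O)c1cc(Oc2cccc(NC(=S)Nc3ccc(OC(F)(F)F)cc3)c2)ccn1` differs from compound 3 in one place: isopropyl in place of methyl on an amide-type nitrogen. The same change has been measured once, from compound 1 to compound 2, where it gave an at least 1.1-fold lower number from compound 1 to compound 2 (0.05 log units; that floor lies within the scatter); with a limit at its starting point, only a floor for that step is known, and that floor lies within the scatter. Nothing shown therefore points to a step beyond the scatter in this assay for compound 4, and a limit rather than a number is a real possibility. The expected step is an at least 1.1-fold lower number from compound 3 to compound 4 (0.04 log units; that floor lies within the scatter), essentially no change. Compound 4 is estimated at 90000 nM, within a range from 45000 nM to 200000 nM.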

Compound 4, half-maximal inhibitory concentration: > 100000 nM
Compound 4: a limit, no number; the forecaster's own chance of this, stated with the estimate: 55%; at least 1.1-fold (0.04 log units) between middle value and limit.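

In this assay compound 4 is reported only as a limit and not a number, so on the trifluoromethoxy side isopropyl in place of methyl on the amide-type nitrogen gives no readable value, whereas on the chloro side compound 2 has a number. Within the data shown here, the steps with a limit at both ends, including the one to compound 4 from its methyl counterpart, cannot be read. Trifluoromethoxy in place of chloro on an aromatic carbon, unreadable in the methyl pair, now has a first bound in the isopropyl pair, an at least 1.1-fold higher number from compound 2 to compound 4 (0.05 log units; that floor lies within the scatter), so only a floor is known and the true size of the change stays open; compound 2 remains the only one of the four with a number, and the others share one boundary: the limit of > 100000 nM in this assay, at which 3 of the 4 values shown sit.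

Open, going by these compounds, is whether a cyclohexyl group or a longer chain on the amide-type nitrogen would bring a number in this assay for the trifluoromethoxy compounds. Also open, on these data alone, is whether an amine or a carboxylic acid in place of chloro or trifluoromethoxy on that aromatic carbon would do so.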